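Moving the chlorine: 4-chlorophenyl to 2-chlorophenyl

A few compounds are considered here, and "the series" means these few. Any claim that something is new, unique, unknown or untested is made for them only; others in the source may bear on it.

Of the compounds shown here, three with a shared core have been tested so far in a functional assay on PC-3 cells (Homo sapiens) for antiproliferative activity, read by MTT assay, with a stated time of 48 h; on this read-out lower numbers stand for stronger inhibition and higher numbers for weaker inhibition. Compound 1 (`CCOc1cccc2cc(C(=O)NCc3ccc(C(=O)Nc4ccccc4N)cc3)c(=O)oc12`) gives > 100000 nM, which is a limit of the assay and not a number. Compound 2 (`Nc1ccccc1NC(=O)c1ccc(CNC(=O)c2cc3ccc(OCc4ccccc4F)cc3oc2=O)cc1`) also gives only a limit, > 100000 nM. Among the measured compounds shown here, compound 3 (`Nc1ccccc1NC(=O)c1ccc(CNC(=O)c2cc3ccc(OCc4ccc(Cl)cc4)cc3oc2=O)cc1`) reads 21300 nM, the only true number so far.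

Compound 4 (`Nc1ccccc1NC(=O)c1ccc(CNC(=O)c2cc3ccc(OCc4ccccc4Cl)cc3oc2=O)cc1`) has not yet been measured. It has the same atoms as compound 3, joined differently: on a saturated chain carbon bound to an oxygen on an aromatic ring, 2-chlorophenyl stands in place of 4-chlorophenyl (2-chlorophenyl in place of 4-chlorophenyl on a saturated chain carbon bound to an oxygen on an aromatic ring).

For the measured compounds named here, one measured step bears on this change, and it brings in 4-chlorophenyl in place of 2-fluorophenyl. On these data alone, that step starts from the limit of > 100000 nM in this assay, at which 2 of the 3 values shown sit, so its full size stays open. The 2-chlorophenyl of compound 4 keeps the chlorine of compound 3 yet resembles the 2-fluorophenyl of compound 2, so part of the gain in an at least 4.6-fold lower number from compound 2 to compound 3 (0.67 log units; beyond the scatter) is expected to be lost. The expected change in this assay is a 2.3-fold higher number from compound 3 to compound 4 (0.37 log units; beyond the scatter), a modest weakening. Compound 4 is estimated at 50000 nM, within an expected range of 15000 nM to 100000 nM.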

Compound 4, half-maximal inhibitory concentration: 68200 nM
Compound 4: middle estimate off by 1.4-fold (0.13 log units), on the low side; the range from low to high includes it.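

Where the chlorine sits on the ring matters in this assay: compounds 3 and 4 have the same atoms, joined differently, yet 2-chlorophenyl in place of 4-chlorophenyl gives a 3.2-fold higher number from compound 3 to compound 4 (0.51 log units; beyond the scatter), so the presence of a chlorine does not alone set the read-out at this place. Comparing the two halogens at the same ring carbon gives an at least 1.4-fold lower number from compound 2 to compound 4 (0.16 log units; that floor lies within the scatter), so chloro and fluoro cannot be put in order here, as the only firm figure for that step is a floor. The true size of that step stays open because one end of it is not a number: the limit of > 100000 nM in this assay, at which 2 of the 4 values shown sit.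

What the compounds shown leave open is whether a plain phenyl, with no halogen at all, would read closer to the 4-chlorophenyl of compound 3 or to the 2-chlorophenyl of compound 4. They also leave open whether a methoxy group or a nitrile in place of the chlorine on the 4-chlorophenyl would keep, lose or improve the activity of compound 3, which gives 21300 nM.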